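The compounds below may be only part of what the source reports. "The series", "measured", "known", "first", "only" and "open" are said of these compounds alone.

Measured compounds in an assay on isolated protein for inhibition of glutathione S-transferase P (Homo sapiens), read by spectrophotometry, with a stated time of 3 min; on this read-out lower numbers stand for stronger inhibition and higher numbers for weaker inhibition:
compound 1 `CCCCCCCCCCO[C@H]1C=C(COC(C)=O)C(=O)[C@@H]2O[C@@](C)(OC)[C@](C)(OC)O[C@@H]12` gives 36500 nM
compound 2 `CO[C@H]1C=C(COC(C)=O)C(=O)[C@@H]2O[C@@](C)(OC)[C@](C)(OC)O[C@@H]12` gives 62700 nM
compound 3 `CO[C@]1(C)O[C@H]2[C@@H](O)C=C(COC(C)=O)C(=O)[C@@H]2O[C@@]1(C)OC` gives 82500 nM

Compound 3 holds the highest number of the three. Its neighbour is compound 2, and the step of a 1.3-fold higher number from compound 2 to compound 3 (0.12 log units; within the scatter) stays within the scatter. Its distance to compound 1 is the step of a 2.3-fold higher number from compound 1 to compound 3 (0.35 log units; beyond the scatter), which lies beyond the scatter, so only the decyl-bearing compound 1 is clearly set apart from compound 3.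

Compound 4 `CO[C@]1(C)O[C@H]2[C@@H](OC/C=C(\C)CCC=C(C)C)C=C(COC(C)=O)C(=O)[C@@H]2O[C@@]1(C)OC` is not yet measured. It differs from compound 3 by 3,7-dimethylocta-2,6-dien-1-yl in place of hydrogen on an oxygen on a saturated carbon. Among the compounds with values here, the steps that bear on this change are the two that remove a chain from the same oxygen: a 2.3-fold higher number from compound 1 to compound 3 (0.35 log units; beyond the scatter) for decyl, a modest step, and a 1.3-fold higher number from compound 2 to compound 3 (0.12 log units; within the scatter) for methyl, within the scatter. The entering 3,7-dimethylocta-2,6-dien-1-yl group is a chain of a length near that of decyl, so the reversal of the decyl step is the nearer guide. Compound 4 is therefore expected to show a modest lower number in this assay than compound 3, the step being a 2.4-fold lower number from compound 3 to compound 4 (0.37 log units; beyond the scatter). For compound 4 the estimate in this assay is 35000 nM, with a range from 15000 nM to 80000 nM.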

Compound 4, half-maximal inhibitory concentration: 179000 nM
Compound 4: the middle estimate sits 5.1-fold (0.71 log units) below what was measured; the whole stated range lies below it.
By their numbers in this assay, from the lowest: compounds 1, 2 and 3 (each within the scatter of the next, the first and the last beyond it); then compound 4.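

At this oxygen on a saturated carbon, a long chain does not in itself bring a lower number in this assay: 3,7-dimethylocta-2,6-dien-1-yl in place of hydrogen gives a 2.2-fold higher number from compound 3 to compound 4 (0.34 log units; beyond the scatter), whereas taking decyl away gives a 2.3-fold higher number from compound 1 to compound 3 (0.35 log units; beyond the scatter), so the two chains move the number in opposite directions. The same chain also stands clearly apart from the smaller and the saturated group, with a 2.9-fold higher number from compound 2 to compound 4 (0.46 log units; beyond the scatter) and a 4.9-fold higher number from compound 1 to compound 4 (0.69 log units; beyond the scatter), which leaves compound 4 as the weakest inhibitor of the four. No measurement is at hand that accounts for this difference between the chains.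

As far as these compounds go, it remains open whether the double bonds or the methyl branches separate this chain from decyl. A saturated 3,7-dimethyloctyl chain or a shorter 3-methylbut-2-en-1-yl chain on the same oxygen would bear on that question.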